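The compounds below may be only part of what the source reports. "The series", "measured", "known", "first", "only" and "open" are said of these compounds alone.

Compound 2 `COC(=O)CNC1=CS(=O)(=O)O[C@@]12[C@@H](CO[Si](C)(C)C(C)(C)C)O[C@@H](n1cc(C)c(=O)n(C)c1=O)[C@@H]2O[Si](C)(C)C(C)(C)C` stands among three close relatives whose tolerance by cells was probed in a functional assay on HEL cells (Homo sapiens) for cytotoxicity, read by microscopy; a higher number here means that more compound is tolerated, a lower number that less compound is tolerated. In this assay compound 2 gives >= 400000 nM, which is a limit of the assay rather than a number. Compound 1 `CC(=O)NC1=CS(=O)(=O)O[C@@]12[C@@H](CO[Si](C)(C)C(C)(C)C)O[C@@H](n1cc(C)c(=O)n(C)c1=O)[C@@H]2O[Si](C)(C)C(C)(C)C` gives >= 80000 nM in this assay, also a limit. Compound 3 `COC(=O)NC1=CS(=O)(=O)O[C@@]12[C@@H](CO[Si](C)(C)C(C)(C)C)O[C@@H](n1cc(C)c(=O)n(C)c1=O)[C@@H]2O[Si](C)(C)C(C)(C)C` gives >= 50000 nM in this assay, again a limit. The steps a step that the two limits leave unreadable from compound 1 to compound 2, a step that the two limits leave unreadable from compound 1 to compound 3 and a step that the two limits leave unreadable from compound 2 to compound 3 therefore cannot be sized. Compound 4 `COC(=O)CC(=O)NC1=CS(=O)(=O)O[C@@]12[C@@H](CO[Si](C)(C)C(C)(C)C)O[C@@H](n1cc(C)c(=O)n(C)c1=O)[C@@H]2O[Si](C)(C)C(C)(C)C` differs from compound 2 by ((methoxycarbonyl)methyl)carbonyl in place of (methoxycarbonyl)methyl on an amine nitrogen. Going by the values given here, no measured step bears on this change, so no shift beyond the scatter is expected, and a limit is again likely. Compound 4 is expected to show the step of an at least 2.6-fold lower number from compound 2 to compound 4 (0.42 log units; beyond the scatter). Compound 4 is therefore estimated at 150000 nM in this assay, with a range from 50000 nM to 400000 nM.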

Compound 4, minimum cytotoxic concentration: 400000 nM
Compound 4: the middle estimate sits 2.7-fold (0.43 log units) below what was measured, within the range that was stated.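

In this assay compound 4 gives 400000 nM, the only plain number among the compounds shown, so this amine nitrogen can carry a group that yields a reading rather than a limit. The value for compound 2 is a limit: the limit of >= 400000 nM in this assay, at which 1 of the 4 values shown sits. Placing ((methoxycarbonyl)methyl)carbonyl on the nitrogen gives a number no higher from compound 2 to compound 4 (the limit leaves the size open), while the steps to compound 4 from compound 1 and compound 3 cannot be read.

Going by these compounds, whether a carboxylic acid in place of the methyl ester would move this number remains open. On these data alone, the effect of a longer chain on this nitrogen remains open too.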